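Swapping the Aryl Group on a Pyrimidine Thioether Hydrazone

A few compounds are considered here, and "the series" means these few. Any claim that something is new, unique, unknown or untested is made for them only; others in the source may bear on it.

Of the compounds shown here, three that share a hydrazone core have been tested in a functional assay on Huh-7 cells (Homo sapiens) for inhibition, read by MTT assay, with a stated time of 72 h; a lower number here means a stronger inhibitor, a higher number a weaker inhibitor. Compound 1 `C/C(=N\NC(=O)c1ccc(CSc2nc3ccccc3s2)cc1)c1ccc(C)c([N+](=O)[O-])c1` gives > 80 ug/mL in this assay, which is a limit and not a number, namely (the limit of > 80 ug/mL in this assay, at which 1 of the 3 values shown sits). Compound 2 `O=C1Nc2ccccc2/C1=N/NC(=O)c1ccc(CSc2nc3ccccc3s2)cc1` gives 4.58 ug/mL in this assay. Compound 3 `C/C(=N\NC(=O)c1ccc(CSc2nc(C)cc(C)n2)cc1)c1ccc(F)cc1` gives 3.25 ug/mL in this assay, and the numbers of compound 3 and compound 2 lie within the usual scatter of one another, so neither stands apart from the other.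

Compound 4 `C/C(=N\NC(=O)c1ccc(CSc2nc(C)cc(C)n2)cc1)c1ccc(C)c([N+](=O)[O-])c1` is the next compound, and it differs from compound 3 in one place: 4-methyl-3-nitrophenyl in place of 4-fluorophenyl on a carbon with a double bond to nitrogen. Going by the values given here, no pair of measured compounds differs by this change alone, so its size cannot be read off directly. Compound 1 carries the same 4-methyl-3-nitrophenyl group and, in this assay, reaches only a limit at > 80 ug/mL. On that basis the step of a 7.7-fold higher number from compound 3 to compound 4 (0.89 log units; beyond the scatter) is expected to run toward weaker inhibition, with a real chance that compound 4 also returns only a limit. Compound 4 is therefore estimated at 25 ug/mL, with an expected range from 6 ug/mL to 80 ug/mL.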

Compound 4, half-maximal inhibitory concentration: > 80 ug/mL
Compound 4 gave a limit, no number (the forecaster's own chance of this, stated with the estimate: 35%); middle value at least 3.2-fold (0.50 log units) away from the limit.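

Going by these compounds alone, on the carbon with a double bond to nitrogen, 4-methyl-3-nitrophenyl in place of 4-fluorophenyl gives an at least 24-fold higher number from compound 3 to compound 4 (1.39 log units; beyond the scatter) in this assay, the first measured pair to show that the group at this position can decide the result on its own. Compound 4 gives > 80 ug/mL, which is a limit of the assay and not a number, so the printed step marks only the smallest size the change can have. Compound 1 and compound 4 both carry 4-methyl-3-nitrophenyl, one with 1,3-benzothiazol-2-yl on the sulfur and the other with 4,6-dimethylpyrimidin-2-yl, and the step between them cannot be read, so the group on the sulfur has no measurable effect here: the limit of > 80 ug/mL in this assay, at which 2 of the 4 values shown sit.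

The compounds shown leave open whether the methyl, the nitro or only the two together carry the loss, which a phenyl ring bearing just one of them, or a plain phenyl, could separate. As far as these compounds go, it also stays open how an amine or a carboxylic acid on that ring would behave, and whether 4-fluorophenyl would hold its value with 1,3-benzothiazol-2-yl on the sulfur.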